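The source may report more compounds than this note shows. Statements on the series, on what has been measured and on what is new or still open speak of the compounds shown alone.

Working notes on the cytotoxicity series. Compound 1 `O=C(NNC(=O)c1cc([N+](=O)[O-])c[nH]1)Nc1ccc([N+](=O)[O-])cc1` gives 211000 nM in an ADME assay on Vero cells (Chlorocebus sabaeus) for cytotoxicity, read by MTT assay, with a stated time of 72 h; a higher number here means a weaker inhibitor, a lower number a stronger inhibitor. Compound 2 `Cn1cc([N+](=O)[O-])cc1C(=O)NNC(=O)NCc1ccco1` gives 482000 nM in this assay, and compound 3 `Cn1cc([N+](=O)[O-])cc1C(=O)NNC(=O)Nc1ccc([N+](=O)[O-])cc1` gives 402000 nM. Among the compounds with values here, all three numbers lie within the usual scatter of one another; compound 3 sits closest to compound 2 and furthest from compound 1, and the one single-point step on record, a 1.9-fold higher number from compound 1 to compound 3 (0.28 log units; within the scatter), lies within the scatter. Compound 4 `COc1ccc(NC(=O)NNC(=O)c2cc([N+](=O)[O-])cn2C)cc1` is the next compound, with the change (methoxy in place of nitro on an aromatic carbon). Within the data shown here, no measured step touches this position of the six-membered ring of carbon only; the only step on record changes a methyl against hydrogen on an aromatic nitrogen and is within the scatter, and compound 2, which carries a different group on the urea nitrogen, shows a number within the scatter of compound 3. Nothing in the series therefore points to a shift of the number beyond the scatter, and the step from compound 3 to compound 4 is expected to be a 1.1-fold lower number from compound 3 to compound 4 (0.02 log units; within the scatter). For compound 4 the estimate in this assay is 380000 nM, in the range 150000 nM to 950000 nM.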

Compound 4, half-maximal inhibitory concentration: 328000 nM
Compound 4: middle estimate off by 1.2-fold (0.06 log units), on the high side; low and high end bracket the measured number.
By their numbers in this assay, from the lowest: compounds 1, 4, 3 and 2 (each within the scatter of the next, the first and the last beyond it).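

In this assay the change on the six-membered aromatic ring of carbon only, methoxy in place of nitro, para to a large group, gives a 1.2-fold lower number from compound 3 to compound 4 (0.09 log units; within the scatter) and so does not separate the two groups at this position. On the amide-type nitrogen, 4-methoxyphenyl in place of (furan-2-yl)methyl gives a 1.5-fold lower number from compound 2 to compound 4 (0.17 log units; within the scatter) and is likewise not separated by this read-out. No supporting data bear on either result.

Still open, from the compounds shown here alone, is whether an amine, a carboxylic acid or a chlorine on this same aromatic carbon would give a step beyond the scatter. Also open, going by these compounds, is whether the methyl on the aromatic nitrogen and the methoxy together would give a number that stands apart from the others.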